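The source may report more compounds than this note shows. Statements on the series, on what has been measured and on what is new or still open speak of the compounds shown alone.

In a functional assay on Bel-7402 cells (Homo sapiens) for antiproliferative activity, read by MTT assay, with a stated time of 72 h (on this read-out higher numbers stand for weaker inhibition and lower numbers for stronger inhibition), compound 1 (`COc1ccc(Cn2c(C(=O)O)c(CNCc3cccc(OC)c3)c3ccccc32)cc1`) gives 52900 nM. Compound 2 (`COc1cccc(CNCc2c(C(=O)O)n(Cc3ccccc3F)c3ccccc23)c1`) is reported only as a limit, > 50000 nM. Compound 3 (`COc1cccc(CNCc2c(C(=O)O)n(Cc3ccc(F)cc3)c3ccccc23)c1`) is also reported only as a limit, > 50000 nM, so it has no exact number of its own. Going by the values given here, the series so far therefore stands at the limit of > 50000 nM in this assay, at which 2 of the 3 values shown sit.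

The next change leads to compound 4 (`COc1cccc(CNCc2c(C(=O)O)n(Cc3ccccc3)c3ccccc23)c1`), with hydrogen in place of fluoro on an aromatic carbon, turning 4-fluorobenzyl into benzyl: hydrogen in place of fluoro on an aromatic carbon. Among the compounds with values here, three measured steps bear on this change, and all concern the same substituent. They are a step that the limit leaves unreadable from compound 1 to compound 2, a step that the limit leaves unreadable from compound 1 to compound 3 and a step that the two limits leave unreadable from compound 2 to compound 3. None of them has a readable size, so they offer no measured effect to carry over to the loss of fluoro.

The firmest anchor is compound 1, which has an exact value of 52900 nM. On that basis, a step that the limit leaves unreadable from compound 3 to compound 4 is expected to stay within the usual scatter, with no direction expected. In this assay, compound 4 is estimated at 55000 nM, with an expected range from 25000 nM to 120000 nM.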

Compound 4, half-maximal inhibitory concentration: > 50000 nM
Compound 4 ended at the assay's limit (the forecaster's own chance of this, stated with the estimate: 60%); the middle value does not contradict the limit.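

In this assay, going by these compounds alone, compound 4 is reported only as a limit, > 50000 nM, so no step linking it to compound 1, compound 2 or compound 3 can be read. The compounds shown leave open whether any of these changes to the benzyl group alters the inhibition, as the series rests largely on one boundary: the limit of > 50000 nM in this assay, at which 3 of the 4 values shown sit.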